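Halogen pattern on the aryl ring: compound 2 to compound 3

The compounds below may be only part of what the source reports. "The series", "measured", "known", "first", "only" and "open" are said of these compounds alone.

Compound 2 `S=C(Nc1ccccc1)N1N=C(c2ccccc2Br)CC1c1ccc2c(c1)OCCO2` stands highest of the two numbers in a functional assay on HCT-116 cells (Homo sapiens) for antiproliferative activity, read by MTT assay, with a stated time of 48 h (on this read-out lower numbers stand for stronger inhibition of growth and higher numbers for weaker inhibition of growth), where compound 2 gives 195000 nM; nearest is compound 1 `S=C(Nc1ccccc1)N1N=C(c2ccccc2)CC1c1ccc2c(c1)OCCO2`, which in this assay gives 57600 nM, the step being a 3.4-fold higher number from compound 1 to compound 2 (0.53 log units; beyond the scatter). Compound 3 `S=C(Nc1ccccc1)N1N=C(c2ccc(Cl)c(Cl)c2)CC1c1ccc2c(c1)OCCO2` differs from compound 2 by 3,4-dichlorophenyl in place of 2-bromophenyl on a carbon with a double bond to nitrogen. For the measured compounds named here, the only measured step, a 3.4-fold higher number from compound 1 to compound 2 (0.53 log units; beyond the scatter), also concerned halogen on that aryl ring and bears on this change only loosely; a halogen remains here, so no step beyond the scatter is firmly expected, with a slight lean to a lower number. Compound 3 is therefore expected at 130000 nM, range 45000 nM to 400000 nM, a step of a 1.5-fold lower number from compound 2 to compound 3 (0.18 log units; within the scatter).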

Compound 3, concentration for 50% growth inhibition: 125000 nM
Compound 3: the middle estimate sits 1.0-fold (0.02 log units) above what was measured, and the stated range covers the measured number.
By their numbers in this assay, from the lowest: compound 1; then compounds 3 and 2 (each within the scatter of the next).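

In this assay, exchanging 2-bromophenyl for 3,4-dichlorophenyl on this carbon gives a 1.6-fold lower number from compound 2 to compound 3 (0.19 log units; within the scatter) and so does not separate the two halogen patterns. Measured against the plain phenyl, the dichloro pattern gives a 2.2-fold higher number from compound 1 to compound 3 (0.34 log units; beyond the scatter), so both halogenated aryl groups shown read weaker than compound 1, whichever halogen or pattern is present. No evidence on the cause of these steps is available. Still open, as far as these compounds go, is whether an amine, a methoxy group or a carboxylic acid on this aryl ring would give a number below that of compound 1. From the compounds shown here alone, a single chlorine also remains open, so the contributions of the two chlorines stay unseparated.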